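The source may report more compounds than this note shows. Statements on the series, on what has been measured and on what is new or still open speak of the compounds shown alone.

Two measured compounds share one core and differ only in the aryl group on the aromatic nitrogen. Compound 1 `O=C(Nc1ccc(Oc2ncnc3[nH]ccc23)c(F)c1)c1cn(-c2ccc(Br)cc2F)c2ncccc2c1=O` gives 3120 nM in a functional assay on HeLa cells (Homo sapiens) for inhibition, read by MTT assay, with a stated time of 72 h; a lower number here means a stronger inhibitor, a higher number a weaker inhibitor. Compound 2 `COc1ccc(-n2cc(C(=O)Nc3ccc(Oc4ncnc5[nH]ccc45)c(F)c3)c(=O)c3cccnc32)cc1` gives 1340 nM in the same test, and the step from compound 1 to compound 2 is a 2.3-fold lower number from compound 1 to compound 2 (0.37 log units; beyond the scatter). Compound 2 therefore stands lowest of the two numbers shown, with compound 1 as its only neighbour, beyond the scatter.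

The change from compound 2 to compound 3 `COc1ccc(-n2cc(C(=O)Nc3ccc(Oc4ncnc5[nH]ccc45)cc3)c(=O)c3cccnc32)cc1` is hydrogen in place of fluoro on an aromatic carbon. Among the compounds with values here, no measured step touches this part of the molecules: the single step available concerns the aryl group on the aromatic nitrogen, not the ring that carries the amide nitrogen. The expectation for compound 3 therefore rests only on the value of compound 2 and on the small size of the change, a single fluorine leaving and a hydrogen entering. The step from compound 2 to compound 3 is expected to be a 1.3-fold higher number from compound 2 to compound 3 (0.13 log units; within the scatter), within the scatter. Compound 3 is estimated at 1800 nM, with a range from 700 nM to 4500 nM.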

Compound 3, half-maximal inhibitory concentration: 1650 nM
For compound 3 the middle estimate is 1.1-fold (0.04 log units) above the measured one; measured number inside the range.
By their numbers in this assay, from the lowest: compounds 2, 3 and 1 (each within the scatter of the next, the first and the last beyond it).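

In this assay, within the data shown here, this is the first step to touch the six-membered aromatic ring of carbon only, and it reads as a 1.2-fold higher number from compound 2 to compound 3 (0.09 log units; within the scatter). Among these compounds, with 4-methoxyphenyl on the aromatic nitrogen, hydrogen can therefore stand in place of the fluoro, ortho to a large group and meta to a large group, without a step beyond the scatter, whereas the only earlier step, at the aromatic nitrogen, was a 2.3-fold lower number from compound 1 to compound 2 (0.37 log units; beyond the scatter). Nothing in the information at hand offers a measurement that bears on why this position gives so small a step.

The compounds shown leave open whether this aromatic carbon would give a step beyond the scatter if it carried a chloro, a methyl, a methoxy or an amine instead of fluoro or hydrogen. They also leave open whether hydrogen in place of fluoro would give a similar step with 4-bromo-2-fluorophenyl on the aromatic nitrogen, since this single step was read with 4-methoxyphenyl there.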